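Two ring stereocentres inverted in a peroxide acid

This account rests on a few compounds, and the source may have more. Where it says the series, first, only, none or still open, it means among the compounds named here.

The set holds three measured compounds: compound 1 `CC(=O)CC/C=C(\C)CCC1=C(C)CCCC1(C)C`, compound 2 `CC1=C(CC/C(C)=C/CC[C@@]2(C)CC[C@@H]([C@H](C)C(=O)O)OO2)C(C)(C)CCC1` and compound 3 `C=C1CCCC(C)(C)C1CC[C@@]1(C)CC[C@H]([C@@H](C)C(=O)O)OO1`. In a functional assay on IGROV-1 cells (Homo sapiens) for inhibition (on this read-out lower numbers stand for stronger inhibition of growth and higher numbers for weaker inhibition of growth), compound 1 gives 9530 nM, compound 2 gives 43600 nM and compound 3 gives 630 nM. Compound 3 thus carries the lowest of the three numbers; its nearest neighbour is compound 1, whose number is higher by a margin beyond the scatter, and compound 2 stands furthest away, also beyond the scatter.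

Compound 4 `C=C1CCCC(C)(C)C1CC[C@]1(C)CC[C@@H]([C@@H](C)C(=O)O)OO1` is not yet measured. It differs from compound 3 in the following way: the two compounds have the same atoms and bonds; at least one stereo element is drawn with a configuration in one of them and without one in the other: 2 of 4 stereo elements differ; a stereocentre at a saturated ring carbon is drawn S in compound 3 and R in compound 4; a stereocentre at a saturated ring carbon is drawn R in compound 3 and S in compound 4. For the measured compounds named here, no pair of measured compounds differs in a single place, so no step of this kind is available as a guide. A change confined to two ring stereocentres gives no direction from the numbers at hand, but an inverted pair of ring stereocentres in this assay is expected to weaken inhibition of growth by a moderate step, a 2.4-fold higher number from compound 3 to compound 4 (0.38 log units; beyond the scatter), with wide uncertainty. Compound 4 is therefore expected to give about 1500 nM, with a range from 400 nM to 8000 nM.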

Compound 4, concentration for 50% growth inhibition: 1730 nM
Beside the measured number, compound 4's estimate is 1.2-fold (0.06 log units) below it; measured number inside the range.
By their numbers in this assay, from the lowest: compound 3; then compound 4; then compound 1; then compound 2.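

In this assay, for the compounds shown here, the step of a 2.7-fold higher number from compound 3 to compound 4 (0.44 log units; beyond the scatter) gives the first comparison between compounds with the same atoms and bonds. It shows that the configuration at these two saturated ring carbons affects inhibition of growth by a margin beyond the scatter, with compound 3 the stronger of the pair and compound 4 still keeping a measurable effect on growth. The reading as a clean inversion carries one reservation, which comes from the drawings themselves: the fact that one of compounds 3 and 4 is drawn with a defined configuration and the other without, at the place where they differ.

The compounds shown leave open which of the two stereocentres carries the step, or whether both contribute to it. They also leave open whether the same preference between the two configurations would hold with a methyl ester or an amide in place of the carboxylic acid.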